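The compounds below may be only part of what the source reports. "The series", "measured", "known", "first", "only" and "open" are said of these compounds alone.

Compound 1 `Oc1ccc2scnc2c1C(c1ccc(F)cc1)N1CCCCC1`; compound 2 `Oc1c(C(c2ccc(F)cc2)N2CCCCC2)ccc2cccnc12`; compound 3 `Oc1cccc(C(Nc2ccccn2)c2ccc3cccnc3c2O)c1Cl`.

Of the compounds shown here, three have been tested in an assay for inhibition of protein disulfide-isomerase (Homo sapiens), with a stated time of 1 h; on this read-out higher numbers stand for weaker inhibition and lower numbers for stronger inhibition. Compound 1 gave only a limit of the assay, > 100000 nM. Compound 2 gave 690 nM. Compound 3 gave 370 nM. Of the two actual numbers, compound 3 holds the lower one, yet compound 2 lies within the usual scatter of it, so the two cannot be told apart on this evidence. The remaining value, that of compound 1, is a limit rather than a number (the limit of > 100000 nM in this assay, at which 1 of the 3 values shown sits).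

Compound 4 `Oc1c(C(Nc2ccccn2)c2ccccc2Cl)ccc2cccnc12` has not yet been measured. It differs from compound 3 in a single place: hydrogen in place of hydroxy on an aromatic carbon. Within the data shown here, no pair of measured compounds is separated by this same change, so there is no measured step to lean on; the group that leaves carries one hydrogen-bond donor and one hydrogen-bond acceptor, and nothing measured here says what that costs or gains. The expectation is therefore a modest step, if any, from compound 3 to compound 4 in this assay, leaning toward weaker inhibition, as a 2.2-fold higher number from compound 3 to compound 4 (0.33 log units; beyond the scatter). Compound 4 is estimated at 800 nM, between 200 nM and 3500 nM.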

Compound 4, half-maximal inhibitory concentration: 500 nM
The estimate for compound 4 lay 1.6-fold (0.20 log units) above the measured number; measured number inside the range.
By their numbers in this assay, from the lowest: compounds 3, 4 and 2 (each within the scatter of the next). At a limit, above all of these: compound 1.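

Exchanging the 2-chloro-3-hydroxyphenyl group for the 2-chlorophenyl group comes in this assay to a 1.4-fold higher number from compound 3 to compound 4 (0.13 log units; within the scatter), so compound 3 and compound 4 cannot be told apart on this evidence. Among these compounds, this is the first comparison of two compounds that differ in one place, and it shows that the hydroxy group, on this aromatic carbon ortho to the chloro group, is not required for a value of this order: its hydrogen-bond donor and acceptor can leave without a difference that exceeds the scatter. Among the compounds shown here, nothing measured so far bears on why this exchange makes so little difference.

Still open, as far as these compounds go, is whether this carbon tolerates any group at all, or whether a methoxy group, an amine or a carboxylic acid in the same place would give a number clearly different from those of compound 3 and compound 4. From the compounds shown here alone, this single step also says nothing about the chloro group next door in the name, so what happens when that chloro group gives way to hydrogen or to a methyl group remains unknown.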